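Methyl for Chloro on the Triazole Aryl of Compound 1

This account rests on a few compounds, and the source may have more. Where it says the series, first, only, none or still open, it means among the compounds named here.

Compound 1 `C=C1C(=O)[C@]23C[C@@]1(O)CC[C@H]2c1ccc(OS(=O)(=O)c2ccc(C)cc2)c(C)c1[C@@H]3Cn1cc(-c2ccc(Cl)cc2)nn1` carries a (4-methylphenyl)sulfonyl on an oxygen on an aromatic ring together with a 4-(4-chlorophenyl)-1H-1,2,3-triazol-1-yl group. In a functional assay on A549 cells (Homo sapiens) for cytotoxicity, read by MTT assay, with a stated time of 4 days (a lower number here means a stronger inhibitor, a higher number a weaker inhibitor), compound 1 gives 1870 nM, the highest of the two numbers recorded. Compound 3 `C=C1C(=O)[C@]23C[C@@]1(O)CC[C@H]2c1ccc(O)c(C)c1[C@@H]3Cn1cc(-c2ccc(Cl)cc2)nn1`, with hydrogen in place of that sulfonyl, gives 640 nM in this assay. That single-point step, a 2.9-fold lower number from compound 1 to compound 3 (0.47 log units; beyond the scatter), is the only one measured. Compound 2 `Cc1ccc(S(=O)(=O)Oc2ccc3c(c2C)[C@H](Cn2cc(-c4ccc(Cl)cc4)nn2)[C@@]24CC(=O)[C@@](C)(CC[C@@H]32)C4)cc1` rests on a different core and reaches only a limit in this assay, > 20000 nM.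

Compound 4 `C=C1C(=O)[C@]23C[C@@]1(O)CC[C@H]2c1ccc(OS(=O)(=O)c2ccc(C)cc2)c(C)c1[C@@H]3Cn1cc(-c2ccc(C)cc2)nn1` differs from compound 1 by methyl in place of chloro on an aromatic carbon. Within the data shown here, no measured step touches that aryl ring; the step from compound 1 to compound 3 concerns the ring oxygen instead. With nothing pointing in either direction, compound 4 is expected to move only a 1.0-fold higher number from compound 1 to compound 4 (0.01 log units; within the scatter), a step that should stay within the scatter. The estimate for compound 4 in this assay is therefore 1900 nM, within 700 nM to 5500 nM.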

Compound 4, half-maximal inhibitory concentration: 1830 nM
The estimate for compound 4 lay 1.0-fold (0.02 log units) above the measured number, within the range that was stated.
By their numbers in this assay, from the lowest: compound 3; then compounds 4 and 1 (each within the scatter of the next). At a limit, above all of these: compound 2.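

In this assay, methyl in place of chloro gives a 1.0-fold lower number from compound 1 to compound 4 (0.01 log units; within the scatter), so on this aromatic carbon, para to a large group, the 4-chlorophenyl and 4-methylphenyl forms cannot be told apart. The earlier compounds shown here spoke only to the oxygen on the aromatic ring, through a 2.9-fold lower number from compound 1 to compound 3 (0.47 log units; beyond the scatter), while compound 4 gives a reading on the aryl of the triazole itself, and here the exchange of one heavy atom for another leaves the number within the scatter. Nothing shown gives a reason for this result.

As far as these compounds go, it remains open whether the same exchange would behave alike with hydrogen in place of the (4-methylphenyl)sulfonyl, as in compound 3. Also open, from the compounds shown here alone, is how an amine or a carboxylic acid on that aromatic carbon would read in this assay.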